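From a chlorophenyl to a pyrrole on the imine carbon

The source may report more compounds than this note shows. Statements on the series, on what has been measured and on what is new or still open speak of the compounds shown alone.

Of the compounds shown here, three sharing one core have been measured in a functional assay on MCF7 cells (Homo sapiens) for inhibition, read by sulforhodamine B assay, with a stated time of 48 h; on this read-out lower numbers stand for stronger inhibition of growth and higher numbers for weaker inhibition of growth. Compound 1 `CC1=CC[C@H](C(C)(C)NC(=S)N/N=C/c2ccccc2O)CC1` gives 17500 nM, compound 2 `CC1=CC[C@H](C(C)(C)NC(=S)N/N=C/c2ccccc2Cl)CC1` gives 98300 nM, and compound 3 `CC1=CC[C@H](C(C)(C)NC(=S)N/N=C/c2cccc(Cl)c2)CC1` gives 61000 nM. Compound 3 thus holds the second highest of the three numbers: a 1.6-fold lower number from compound 2 to compound 3 (0.21 log units; within the scatter), whereas a 3.5-fold higher number from compound 1 to compound 3 (0.54 log units; beyond the scatter). Compound 4 `CC1=CC[C@H](C(C)(C)NC(=S)N/N=C/c2ccc[nH]2)CC1` differs from compound 3 in one place: 1H-pyrrol-2-yl in place of 3-chlorophenyl on a carbon with a double bond to nitrogen. For the measured compounds named here, no measured step exchanges a six-membered ring for a five-membered one, so the measured steps bear on this change only loosely; the step of a 3.5-fold higher number from compound 1 to compound 3 (0.54 log units; beyond the scatter) hints that a ring carrying a hydrogen-bond donor may go with a lower number. Compound 4 is therefore expected to give 45000 nM, between 15000 nM and 140000 nM, an estimated step of a 1.4-fold lower number from compound 3 to compound 4 (0.13 log units; within the scatter).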

Compound 4, concentration for total growth inhibition: 11500 nM
Beside the measured number, compound 4's estimate is 3.9-fold (0.59 log units) above it; the whole stated range lies above it.
By their numbers in this assay, from the lowest: compounds 4 and 1 (each within the scatter of the next); then compounds 3 and 2 (each within the scatter of the next).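

In (this assay), a five-membered ring on the carbon with a double bond to nitrogen is tolerated: 1H-pyrrol-2-yl replaces 3-chlorophenyl (a 5.3-fold lower number from compound 3 to compound 4 (0.72 log units; beyond the scatter)) and 2-chlorophenyl (an 8.5-fold lower number from compound 2 to compound 4 (0.93 log units; beyond the scatter)) with a clear gain. Set against 2-hydroxyphenyl (a 1.5-fold lower number from compound 1 to compound 4 (0.18 log units; within the scatter)), it stands level, so the two compounds whose ring carries a hydrogen-bond donor group together at lower numbers than both chlorophenyl compounds. Nothing measured here gives a reason for this grouping.

Going by these compounds, whether the hydrogen on the pyrrole nitrogen matters stays open. A 1-methylpyrrol-2-yl or a furan-2-yl group would speak to that.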